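A few compounds are considered here, and "the series" means these few. Any claim that something is new, unique, unknown or untested is made for them only; others in the source may bear on it.

Measured so far in a functional assay on cells (Homo sapiens) for inhibition; a higher number here means a weaker inhibitor, a lower number a stronger inhibitor:
- compound 1 `O=C(/C=C\N(O)Cc1ccccc1)c1ccc(Cl)c(Cl)c1`: 3600 nM
- compound 2 `O=C(/C=C\N(O)Cc1ccc(-c2ccccc2)cc1)C1CC1`: > 10000 nM

Within the data shown here, compound 1 at 3600 nM holds the only actual number, so it has no measured neighbour to be ranked against. Compound 2 reads > 10000 nM, which is a limit of the assay and not a number.

Next in this assay is compound 3 `O=C(/C=C\N(O)Cc1ccccc1)c1ccc(Cl)cc1`, which differs from compound 1 in one place: hydrogen in place of chloro on an aromatic carbon. Among the measured compounds shown here, no measured pair shows what this change does, so the size of the step is a judgement. A modest weakening is expected, perhaps only just beyond the usual scatter, and no change at all would not surprise. The expected move is a 1.7-fold higher number from compound 1 to compound 3 (0.22 log units; within the scatter). For compound 3 the estimated value is 6000 nM, with an expected range of 2500 nM to 12000 nM.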

Compound 3, half-maximal inhibitory concentration: 2100 nM
The estimate for compound 3 lay 2.9-fold (0.46 log units) above the measured number, outside the stated range (below it).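

In this assay, among these compounds, the first one-place pair gives a 1.7-fold lower number from compound 1 to compound 3 (0.23 log units; within the scatter). On the aromatic carbon ortho to a chloro group and meta to a large group, chloro can therefore be exchanged for hydrogen without a difference that stands clear of the scatter, and the second chloro group of compound 1 is not required to hold inhibition in this range. Nothing at hand bears on the reason for this outcome.

Among the compounds shown here, what the remaining chloro group of compound 3 contributes stays open, as no pair shows it exchanged for hydrogen or for another group. Also open, as far as these compounds go, is how a larger or differently built group at the exchanged position, such as methoxy, nitrile or an amine, would read in this assay.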